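Methylsulfanyl in Place of Trifluoromethyl: Expected Growth Inhibition

This account rests on a few compounds, and the source may have more. Where it says the series, first, only, none or still open, it means among the compounds named here.

Compound 1 `S=C(Nc1ccccc1)N1N=C(c2ccccc2)CC1c1ccc2c(c1)OCCO2`: 1850 nM in a functional assay on A-375 cells (Homo sapiens) for antiproliferative activity, read by MTT assay, with a stated time of 48 h; a higher number here means a weaker inhibitor of growth, a lower number a stronger inhibitor of growth
Compound 2 `S=C(Nc1ccccc1)N1N=C(c2ccc(Cl)cc2)CC1c1ccc2c(c1)OCCO2`: 195000 nM
Compound 3 `FC(F)(F)c1ccc(C2=NN(C(=S)Nc3ccccc3)C(c3ccc4c(c3)OCCO4)C2)cc1`: 43500 nM

Compound 3 stands second highest of the three in this assay: compound 2 gives a higher number, compound 1 a lower one. Compound 4 `CSc1ccc(C2=NN(C(=S)Nc3ccccc3)C(c3ccc4c(c3)OCCO4)C2)cc1` differs from compound 3 by methylsulfanyl in place of trifluoromethyl on an aromatic carbon. Within the data shown here, no measured step makes this exact exchange. Among the measured compounds shown here, the steps that bear on it are a 110-fold higher number from compound 1 to compound 2 (2.02 log units; beyond the scatter) and a 24-fold higher number from compound 1 to compound 3 (1.37 log units; beyond the scatter), both large losses of growth inhibition when a group is added at this position, and a 4.5-fold lower number from compound 2 to compound 3 (0.65 log units; beyond the scatter), a modest difference between two such groups. Compound 4 is therefore expected to stay weak, at about 40000 nM, with a range of 8000 nM to 200000 nM. The expected step is a 1.1-fold lower number from compound 3 to compound 4 (0.04 log units; within the scatter), within the scatter.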

Compound 4, concentration for 50% growth inhibition: 159000 nM
Estimate against measurement, compound 4: 4.0-fold (0.60 log units) below; the range from low to high includes it.
By their numbers in this assay, from the lowest: compound 1; then compound 3; then compounds 4 and 2 (each within the scatter of the next).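

With an 86-fold higher number from compound 1 to compound 4 (1.93 log units; beyond the scatter) methylsulfanyl joins chloro and trifluoromethyl as a third group at this position that leaves growth inhibition far weaker than hydrogen does. The exchange for trifluoromethyl has a real effect, as a 3.7-fold higher number from compound 3 to compound 4 (0.56 log units; beyond the scatter) lies beyond the usual scatter. Methylsulfanyl and chloro cannot be told apart, since a 1.2-fold lower number from compound 2 to compound 4 (0.09 log units; within the scatter) lies within it.

Nothing given here explains these differences. Going by these compounds, whether an amine, a hydroxyl or fluoro at this position would keep the growth inhibition of compound 1 stays open.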